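The compounds below may be only part of what the source reports. "The series", "measured", "known", "first", "only" and "open" are said of these compounds alone.

Working notes on the series. Three members have been measured so far: compound 1 `COc1ccc(N2CCN(Cc3csc(N)c3C(=O)c3ccc(Cl)cc3)CC2)cc1`, compound 2 `Nc1scc(CN2CCN(c3cccc(C(F)(F)F)c3)CC2)c1C(=O)c1ccc(Cl)cc1` and compound 3 `Nc1scc(CN2CCN(c3ccccc3C(F)(F)F)CC2)c1C(=O)c1ccc(Cl)cc1`, which share one core and differ only in the group on an amine nitrogen in a ring. In a functional assay on CHO cells with adenosine receptor A1 (Homo sapiens) as the target, read by cAMP accumulation and immunoassay, with a stated time of 6 min, tested at 1 uM (on this read-out lower numbers stand for a stronger effect and higher numbers for a weaker effect at the one concentration tested), compound 1 gives -15%, compound 2 gives -72% and compound 3 gives -39%. Compound 3 therefore stands second highest of the three numbers; its position follows from a number 24 percentage points lower from compound 1 to compound 3 (beyond the scatter) and from a number 33 percentage points higher from compound 2 to compound 3 (beyond the scatter). The third step, a number 57 percentage points lower from compound 1 to compound 2 (beyond the scatter), is the largest of the set.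

The next member, compound 4 `Nc1scc(CN2CCN(c3cccc4ccccc34)CC2)c1C(=O)c1ccc(Cl)cc1`, differs from compound 3 by naphthalen-1-yl in place of 2-(trifluoromethyl)phenyl on an amine nitrogen in a ring. Within the data shown here, no measured step brings in naphthalen-1-yl, so the three measured steps bear on it only indirectly: each changes the same kind of group on the same ring nitrogen, and each moves the read-out beyond the scatter, from a modest step to a large one. A shift beyond the scatter is thus expected in this assay for compound 4 as well, while the direction is left open by the data. Compound 4 is estimated to give about -45%, with a range from -80% to -10%. The step this implies, a number 6 percentage points lower from compound 3 to compound 4 (within the scatter), is an expectation only.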

Compound 4, a percentage reported as activity, at one concentration (the size of the read-out at that concentration, not a potency): 2.9%
Beside the measured number, compound 4's estimate is 47.9 percentage points below it; measured number outside the range, above it.
By their numbers in this assay, from the lowest: compound 2; then compound 3; then compound 1; then compound 4.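

In this assay, among these compounds, naphthalen-1-yl is the only one of the four groups on this ring nitrogen to give a positive number, and it lies on the weaker side of every other member: a number 41.9 percentage points higher from compound 3 to compound 4 (beyond the scatter), a number 74.9 percentage points higher from compound 2 to compound 4 (beyond the scatter) and a number 17.9 percentage points higher from compound 1 to compound 4 (beyond the scatter). Naphthalen-1-yl and 2-(trifluoromethyl)phenyl have the same heavy-atom count and neither has hydrogen-bond donors or acceptors, so the large step from compound 3 comes with no change in those counts, only with a second aromatic ring of carbon in place of the trifluoromethyl group. Nothing available on these compounds accounts for the change at this position.

The compounds shown do not separate the effect of adding the second aromatic ring from that of removing trifluoromethyl, a question that unsubstituted phenyl, 2-methylphenyl and naphthalen-2-yl on the same nitrogen would address. Also open, on these data alone, is whether these differences at a single concentration would hold across a full concentration range, since the read-out gives the size of the effect at that concentration and not a potency.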